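A few compounds are considered here, and "the series" means these few. Any claim that something is new, unique, unknown or untested is made for them only; others in the source may bear on it.

Compound 1 `CCC1(CCCCN2CCN(c3cccc(Cl)c3)CC2)C(=O)Nc2ccccc21` belongs to a small set of aryl piperazines built on a shared core, and in an assay on CHO cells for displacement of a labelled ligand from 5-hydroxytryptamine receptor 7 (Homo sapiens) (on this read-out higher numbers stand for weaker inhibition and lower numbers for stronger inhibition), compound 1 gives 0.41 nM. Of the two numbers on record it is the lower one; compound 2 `CCC1(CCCCN2CCN(c3cccc(Cl)c3)CC2)C(=O)Nc2c(Cl)cc(Cl)cc21`, which carries two chloro groups on the core, gives 9.46 nM in this assay, a step that lies beyond the scatter. Compound 3 `CCC1(CCCCN2CCN(c3ccc(Cl)cc3)CC2)C(=O)Nc2ccccc21`, with the chloro group moved to another position of the aryl ring, gives 0.38 nM; 0.38 nM (2 entries) in this assay, a value within the scatter of compound 1, so the two cannot be ordered.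

Compound 4 `CCC1(CCCCN2CCN(c3ccc(C)c(Cl)c3)CC2)C(=O)Nc2ccccc21` has not yet been measured. It differs from compound 1 by a methyl group entering on the aryl ring, (methyl in place of hydrogen on an aromatic carbon).

Among the compounds with values here, nothing among the measured compounds shows how such a methyl group acts. Compound 4 is expected to give a number close to that of compound 1, with a step of a 1.5-fold higher number from compound 1 to compound 4 (0.17 log units; within the scatter) that should stay within the scatter. The estimate for compound 4 in this assay is 0.6 nM, expected between 0.2 nM and 2 nM.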

Compound 4, inhibition constant: 0.66 nM
For compound 4 the middle estimate is 1.1-fold (0.04 log units) below the measured one; low and high end bracket the measured number.
By their numbers in this assay, from the lowest: compounds 1 and 4 (each within the scatter of the next); then compound 2.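

In this assay, within the data shown here, the first change on the aryl ring that adds a group rather than moves one gives a 1.6-fold higher number from compound 1 to compound 4 (0.21 log units; within the scatter). A methyl group on this aromatic carbon, ortho to a chloro group and para to a large group, therefore leaves the number for the 3-chloro-4-methylphenyl compound not separable from that for the 3-chlorophenyl compound, and the position takes this one added carbon with no step beyond the scatter. Nothing on record explains this result or ties it to any property of the methyl group.

The compounds shown leave open whether a methoxy group, an amine or a carboxylic acid at this same position would also stay within the scatter of compound 1. They also leave open whether the methyl group would give a similar step on the dichloro core of compound 2.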